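The source may hold more compounds than are shown below. What is called first, only, known or untested is meant among the compounds shown, and "the series" means these compounds.

Working notes on the series. Compound 1 `CC(=O)N(C)C(C)C#CCn1ccnc1` is the reference. In a functional assay on the whole organism for agonist activity, with Mus musculus as the target (on this read-out lower numbers stand for an effect already at smaller amounts and higher numbers for an effect only at larger amounts of compound), compound 1 gives 2 mg/kg. Compound 2 `CC(=O)N(C)C(C)C#CCn1cncc1C` carries the same core with one change, (methyl in place of hydrogen on an aromatic carbon). In this assay compound 2 gives only a limit, > 100 mg/kg, not a number. The measured step is an at least 50-fold higher number from compound 1 to compound 2 (1.69 log units; beyond the scatter). Compound 3 `CC1CCC(=O)N1CC#CCn1ccnc1` rests on a different core; the difference between the two cores is not broken down here. In this assay compound 3 also gives only a limit, > 100 mg/kg. Thus two of the three values so far sit at the limit of > 100 mg/kg in this assay, at which 2 of the 3 values shown sit.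

Compound 4 `Cc1cncn1CC#CCN1C(=O)CCC1C` is not yet measured. It stands to compound 3 as compound 2 stands to compound 1: methyl in place of hydrogen on an aromatic carbon, the same change, at the same place. For the measured compounds named here, only one measured instance of this change exists, and it pushed the read-out past the working range. The expected step is a step that the limit leaves unreadable from compound 3 to compound 4, resting on compound 3 already sitting at its limit > 100 mg/kg and on the direction seen in an at least 50-fold higher number from compound 1 to compound 2 (1.69 log units; beyond the scatter). For compound 4 in this assay the estimate is 300 mg/kg, spanning 100 mg/kg to 1000 mg/kg, most likely reported again as a limit only.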

Compound 4, dose for half-maximal effect: > 100 mg/kg
Compound 4: a limit, no number; the forecaster's own chance of this, stated with the estimate: 90%; the middle value lies beyond the limit too.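

In this assay compound 4 gives only a limit (> 100 mg/kg). No step from compound 3 to compound 4 can be read, and the series now stands with this: the limit of > 100 mg/kg in this assay, at which 3 of the 4 values shown sit.

The compounds shown leave open how far compound 2, compound 3 and compound 4 lie past that limit, and so whether methyl in place of hydrogen changes anything on the core of compound 3.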